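Triazole esters of a triterpenoid core, all at the limit

This account rests on a few compounds, and the source may have more. Where it says the series, first, only, none or still open, it means among the compounds named here.

Compound 1 `C/C(=C\CC/C(C)=C/CC[C@@H]1[C@@]2(C)CCC(=O)C(C)(C)[C@H]2CC[C@@]1(C)O)CC/C=C(\C)C(=O)OCc1cn(-c2ccccc2Cl)nn1`: in a functional assay on DU-145 cells (Homo sapiens) for antiproliferative activity, read by MTT assay, with a stated time of 48 h (a lower number here means a stronger inhibitor, a higher number a weaker inhibitor), compound 1 gives > 150000 nM, which is a limit of the assay rather than a number.
Compound 2 `C/C(=C\CC/C(C)=C/CC[C@@H]1[C@@]2(C)CCC(=O)C(C)(C)[C@H]2CC[C@@]1(C)O)CC/C=C(\C)C(=O)OCc1cn(-c2ccccc2C(F)(F)F)nn1`: in this assay compound 2 gives > 150000 nM, again only a limit.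
Compound 3 `C/C(=C\CC/C(C)=C/CC[C@@H]1[C@@]2(C)CCC(=O)C(C)(C)[C@H]2CC[C@@]1(C)O)CC/C=C(\C)C(=O)OCc1cn(-c2ccccc2Br)nn1`: in this assay compound 3 gives > 150000 nM, again only a limit.

Compound 2 therefore stands nowhere on a numerical scale; it sits at the same limit as every other value shown, since (the limit of > 150000 nM in this assay, at which 3 of the 3 values shown sit). The three steps among the measured compounds, a step that the two limits leave unreadable from compound 1 to compound 2, a step that the two limits leave unreadable from compound 1 to compound 3 and a step that the two limits leave unreadable from compound 2 to compound 3, cannot be read in size. Each of them joins two limits.

Compound 4 `COc1ccc(-n2cc(COC(=O)/C(C)=C/CC/C(C)=C/CC/C(C)=C/CC[C@@H]3[C@@]4(C)CCC(=O)C(C)(C)[C@H]4CC[C@@]3(C)O)nn2)cc1` carries a different group on the same position: 4-methoxyphenyl in place of 2-(trifluoromethyl)phenyl on an aromatic nitrogen. Going by the values given here, no measured step touches this change, so no direction can be read from the data. Given that every shown value is a limit, compound 4 is also expected to return a limit. The step of a number no higher from compound 2 to compound 4 (the limit leaves the size open) is expected to be no larger than the scatter. The estimate for compound 4 is 150000 nM, with a range from 60000 nM to 400000 nM.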

Compound 4, half-maximal inhibitory concentration: 135000 nM
Beside the measured number, compound 4's estimate is 1.1-fold (0.05 log units) above it, and the stated range covers the measured number.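

Going by these compounds alone, compound 4 is the first compound here to return a number rather than a limit in this assay, so this position on the aromatic nitrogen can hold a group that gives a readable value. The change to 4-methoxyphenyl gives an at least 1.1-fold lower number from compound 2 to compound 4 (0.04 log units; that floor lies within the scatter), an at least 1.1-fold lower number from compound 3 to compound 4 (0.04 log units; that floor lies within the scatter) and an at least 1.1-fold lower number from compound 1 to compound 4 (0.04 log units; that floor lies within the scatter). Each of these steps has a limit at one end, so it gives only a floor and the true size stays open: the limit of > 150000 nM in this assay, at which 3 of the 4 values shown sit.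

The compounds shown cannot separate the effect of the methoxy group from that of its place on the phenyl ring. On these data alone, how an amine or a carboxylic acid on that phenyl ring would read in this assay also stays open.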